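From 2-chlorophenyl to 3-chlorophenyl on a shared core

The source may report more compounds than this note shows. Statements on the series, on what has been measured and on what is new or still open speak of the compounds shown alone.

Among the measured compounds shown here, in an ADME assay on MT4 cells (Homo sapiens) for cytotoxicity, read by MTT assay, with a stated time of 4 days (on this read-out higher numbers stand for lower toxicity in this test and lower numbers for higher toxicity in this test), only two compounds have numbers so far. There compound 1 (`O=C(COc1cccc2ccccc12)N/N=C/c1cccc([N+](=O)[O-])c1`) gives 12.1 ug/mL while compound 2 (`O=C(COc1cccc2ccccc12)N/N=C/c1ccccc1Cl`) gives 56.2 ug/mL and so holds the higher of the two numbers. Its gap to compound 1 lies beyond the usual scatter.

Compound 3 (`O=C(COc1cccc2ccccc12)N/N=C/c1cccc(Cl)c1`) has not yet been measured. It has the same atoms as compound 2, joined differently, with 3-chlorophenyl in place of 2-chlorophenyl on a carbon with a double bond to nitrogen. For the measured compounds named here, no measured step shows what such a change does, so the expectation is loose and rests only on the two values, with compound 2 at the top of the span they mark. In this assay the change is expected to be small, staying within the scatter or close to its edge, and to lean toward a lower number. The expected step is a 1.9-fold lower number from compound 2 to compound 3 (0.27 log units; within the scatter) on this estimate. Compound 3 is estimated at 30 ug/mL with an expected range from 10 ug/mL to 90 ug/mL for the measurement to come.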

Compound 3, half-maximal cytotoxic concentration: 89.9 ug/mL
Compound 3: middle estimate off by 3.0-fold (0.48 log units), on the low side, and the stated range covers the measured number.
By their numbers in this assay, from the lowest: compound 1; then compounds 2 and 3 (each within the scatter of the next).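

In this assay the shift to 3-chlorophenyl in place of 2-chlorophenyl on a carbon with a double bond to nitrogen gives a 1.6-fold higher number from compound 2 to compound 3 (0.20 log units; within the scatter) and so leaves the two compounds indistinguishable on this read-out. Among the compounds shown here, the new compound also supplies the first readable step on the identity of the group: chloro in place of nitro on an aromatic carbon gives a 7.4-fold higher number from compound 1 to compound 3 (0.87 log units; beyond the scatter) and so, unlike the shift between the two chlorophenyl forms, moves the number beyond the scatter. No measurement at hand bears on why either step has the size it has.

What the compounds shown leave open is where other groups on that aromatic carbon would fall, such as an amine, a methoxy group or a carboxylic acid, and whether they would stand with compound 1 or with the two chloro compounds. Also open, going by these compounds, is whether the step from nitro to chloro would keep its size if the shared core carried a change elsewhere, such as a longer chain.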